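The source may hold more compounds than are shown below. What is called first, only, known or untested is meant among the compounds shown, and "the series" means these compounds.

Compound 2 `COc1cccc(CNCCCNc2ccnc3cc(CC(C)C)ccc23)c1O` and compound 3 `COc1ccc(F)cc1CNCCCNc1ccnc2cc(CC(C)C)ccc12` share one core and differ in the group on the saturated chain carbon: 5-fluoro-2-methoxyphenyl in place of 2-hydroxy-3-methoxyphenyl on a saturated chain carbon bound to an amine nitrogen. In an ADME assay for permeability, using PAMPA, with a stated time of 30 min, at pH 7.4 (on this read-out higher numbers stand for higher permeability and lower numbers for lower permeability), compound 2 gives 23 10^-6 cm/s, while compound 3 gives 23 10^-6 cm/s, so that exchange produced no change at the digits printed from compound 2 to compound 3 (within the scatter). Compound 1 `COc1cccc(CNCCCNc2ccnc3cc(Oc4ccccc4)ccc23)c1O` carries phenoxy in place of isobutyl on an aromatic carbon; in this assay compound 1 gives 317 10^-6 cm/s, which amounts to a 14-fold higher number from compound 2 to compound 1 (1.14 log units; beyond the scatter). Compound 4 `COc1ccc(F)cc1CNCCCNc1ccnc2cc(Oc3ccccc3)ccc12` has not yet been measured in this assay. It differs from compound 3 by phenoxy in place of isobutyl on an aromatic carbon, the same change that separates compound 1 from compound 2, made at the same place on the core. Compound 4 is expected to show a 13-fold higher number from compound 3 to compound 4 (1.12 log units; beyond the scatter) because the same change gave a 14-fold higher number from compound 2 to compound 1 (1.14 log units; beyond the scatter). Compound 4 is therefore estimated at 300 10^-6 cm/s, with the likely range running from 150 10^-6 cm/s to 500 10^-6 cm/s.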

Compound 4, apparent permeability: 317 10^-6 cm/s
Compound 4: middle estimate off by 1.1-fold (0.02 log units), on the low side; the range from low to high includes it.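

In this assay, phenoxy in place of isobutyl on an aromatic carbon gave a 14-fold higher number from compound 3 to compound 4 (1.14 log units; beyond the scatter), and this step matched the one seen on the other core: the same change on two cores in this assay, a 14-fold higher number (1.14 log units; beyond the scatter) from compound 2 to compound 1 and a 14-fold higher number (1.14 log units; beyond the scatter) from compound 3 to compound 4, 1.0-fold (0.00 log units) apart, within the scatter of two such steps The exchange of 2-hydroxy-3-methoxyphenyl for 5-fluoro-2-methoxyphenyl gave no change at the digits printed from compound 1 to compound 4 (within the scatter), and it likewise read the same with either group on the aromatic carbon: the same change on two cores in this assay, no change at the digits printed (within the scatter) from compound 2 to compound 3 and no change at the digits printed (within the scatter) from compound 1 to compound 4, 1.0-fold (0.00 log units) apart, within the scatter of two such steps Within these four compounds the two changes therefore add up cleanly, but this rests on a single pair of steps for each change and does not show that either would carry over to other cores or explain the size of the steps.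

The compounds shown leave open whether an amine or a carboxylic acid on that aromatic carbon would follow the same pattern. They also leave open whether it would hold with a longer chain in the linker.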